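Swapping a six-membered lactam for a tethered imidazole

The source may report more compounds than this note shows. Statements on the series, on what has been measured and on what is new or still open speak of the compounds shown alone.

Of the compounds shown here, three sharing one core have been tested in an ADME assay on microsomes from liver (Homo sapiens) for metabolic stability; on this read-out lower numbers stand for a shorter-lived compound and higher numbers for a longer-lived compound. Compound 1 `CC(C)C(c1ncc[nH]1)c1ccc(-c2ccc3cccc(F)c3c2)[nH]c1=O` carries a 1H-imidazol-2-yl group on a saturated chain carbon bound to an aromatic carbon and a saturated chain carbon. In this assay compound 1 gives only a limit, < 0.0667 h, not a number (the limit of < 0.0667 h in this assay, at which 1 of the 3 values shown sits). Compound 2 `CC(C)NC(=O)CC(c1ccc(-c2ccc3cccc(F)c3c2)[nH]c1=O)C(C)C` gives 0.32 h in this assay. Compound 3 `CC(C)C(c1ccc(-c2ccc3cccc(F)c3c2)[nH]c1=O)N1CCCCC1=O` gives 0.183 h in this assay. Compound 3 and compound 2 therefore sit close together, since a 1.7-fold lower number from compound 2 to compound 3 (0.24 log units; within the scatter), and the third value is a limit rather than a number.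

Compound 4 `CC(C)C(Cc1ncc[nH]1)c1ccc(-c2ccc3cccc(F)c3c2)[nH]c1=O` differs from compound 3 in a single place ((1H-imidazol-2-yl)methyl in place of 2-oxopiperidin-1-yl on a saturated chain carbon bound to an aromatic carbon and a saturated chain carbon). The imidazole ring of compound 1 thus returns, now as (1H-imidazol-2-yl)methyl. Among the compounds with values here, two measured steps bear on this. Going from the imidazole to the other groups lengthened the half-life clearly: an at least 2.7-fold higher number from compound 1 to compound 3 (0.43 log units; beyond the scatter) and an at least 4.7-fold higher number from compound 1 to compound 2 (0.68 log units; beyond the scatter). Reversing that direction, a drop beyond the scatter is expected for compound 4, namely a 2.3-fold lower number from compound 3 to compound 4 (0.36 log units; beyond the scatter). The half-life of compound 4 in this assay is estimated at 0.08 h, expected to lie between 0.04 h and 0.2 h, with a real chance that only a limit is reported.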

Compound 4, half-life: 0.106 h
Estimate against measurement, compound 4: 1.3-fold (0.12 log units) below; measured number inside the range.
By their numbers in this assay, from the lowest: compounds 4, 3 and 2 (each within the scatter of the next, the first and the last beyond it). At a limit, below all of these: compound 1.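

In this assay, (1H-imidazol-2-yl)methyl and 2-oxopiperidin-1-yl cannot be told apart at this position (a 1.7-fold lower number from compound 3 to compound 4 (0.24 log units; within the scatter)), yet the imidazole-bearing compound does fall clearly short of the isopropylcarbamoyl side chain (a 3.0-fold lower number from compound 2 to compound 4 (0.48 log units; beyond the scatter)). So compound 2 and compound 4 form the only pair here with two real numbers that lie clearly apart, and the lactam of compound 3 sits within the scatter of both. Placing a methyl link between the imidazole ring and the chain carbon gives only a floor (an at least 1.5-fold higher number from compound 1 to compound 4 (0.20 log units; that floor lies within the scatter)), so these compounds do not show whether that link changes the half-life. Compound 1 remains a limit, not a number: the limit of < 0.0667 h in this assay, at which 1 of the 4 values shown sits.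

The compounds shown leave open whether a longer chain between the imidazole ring and the chain carbon, or an amine or a carboxylic acid at the same place, would move the half-life beyond the scatter. A pyrazole or triazole ring there would test whether the short half-lives follow the imidazole ring specifically or aromatic rings containing nitrogen more generally.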